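This account rests on a few compounds, and the source may have more. Where it says the series, first, only, none or still open, it means among the compounds named here.

Measured so far in a functional assay on HCT-15 cells (Homo sapiens) for inhibition; a lower number here means a stronger inhibitor, a higher number a weaker inhibitor:
- Compound 1, `Oc1ccc(-c2cc(-c3cccc(F)c3)cc(-c3cccc(O)c3)n2)cc1`, gives 3070 nM
- Compound 2, `Oc1cccc(-c2cc(-c3cccc(C(F)(F)F)c3)cc(-c3ccccc3O)n2)c1`, gives 6460 nM
- Compound 3, `Oc1cccc(-c2cc(-c3cccc(C(F)(F)F)c3)cc(-c3cccc(O)c3)n2)c1`, gives 13600 nM

Compound 3 stands at the highest number of the three, meaning the weakest inhibition. Its nearest neighbour is compound 2, and the step of a 2.1-fold higher number from compound 2 to compound 3 (0.32 log units; beyond the scatter) is modest but beyond the scatter. Compound 1 lies furthest away, with a number clearly lower than that of compound 3.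

Compound 4, `Oc1ccc(-c2cc(-c3cccc(C(F)(F)F)c3)cc(-c3cccc(O)c3)n2)cc1`, differs from compound 3 in one place: 4-hydroxyphenyl in place of 3-hydroxyphenyl on an aromatic carbon. For the measured compounds named here, only one measured step bears on moving a hydroxyl around this ring, a 2.1-fold higher number from compound 2 to compound 3 (0.32 log units; beyond the scatter), and it went in the direction of weaker inhibition when the hydroxyl moved from the 2-position to the 3-position. Compound 1, which also carries a 4-hydroxyphenyl but a fluoro group rather than a trifluoromethyl group, gives the lowest number of the three, which points the same way. Taken together, a modest step toward stronger inhibition is expected, a 2.5-fold lower number from compound 3 to compound 4 (0.39 log units; beyond the scatter), and compound 4 is estimated at 5500 nM, with a range from 2000 nM to 14000 nM.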

Compound 4, half-maximal inhibitory concentration: 9540 nM
Beside the measured number, compound 4's estimate is 1.7-fold (0.24 log units) below it; measured number inside the range.
By their numbers in this assay, from the lowest: compound 1; then compounds 2, 4 and 3 (each within the scatter of the next, the first and the last beyond it).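

In this assay, the hydroxyl position on the ring attached next to the ring nitrogen matters little once compound 4 is included: 4-hydroxyphenyl replaces 3-hydroxyphenyl with a 1.4-fold lower number from compound 3 to compound 4 (0.15 log units; within the scatter) and replaces 2-hydroxyphenyl with a 1.5-fold higher number from compound 2 to compound 4 (0.17 log units; within the scatter), so compound 4 cannot be separated from either neighbour. The clearer change lies on the other ring, where trifluoromethyl in place of fluoro gives a 3.1-fold higher number from compound 1 to compound 4 (0.49 log units; beyond the scatter), so the low number of compound 1 goes with its fluoro group and not with its 4-hydroxyphenyl. Nothing available here explains either result.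

The compounds shown leave open whether an amine or a methoxy group in place of this hydroxyl would move the number. They also leave open whether a chlorine or a nitrile in place of the fluoro group would keep the lower number of compound 1.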